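The source may report more compounds than this note shows. Statements on the series, on what has been measured and on what is new or still open speak of the compounds shown alone.

Going by the values given here, compound 2 `Cc1ccc(OCC(=O)N2CCN(c3ccc(C(F)(F)F)cc3[C@@H](N)CC(C)C)CC2)cc1` gives 4400 nM in an assay on HEK293 cells for displacement of a labelled ligand from Melanocortin receptor 4 (Homo sapiens) (on this read-out higher numbers stand for weaker inhibition and lower numbers for stronger inhibition), the higher of the two numbers measured so far; compound 1 `CC(C)C[C@H](N)c1cc(C(F)(F)F)ccc1N1CCN(C(=O)COc2ccc3ccccc3c2)CC1` gives 2000 nM in this assay, and the step of a 2.2-fold higher number from compound 1 to compound 2 (0.34 log units; beyond the scatter) is the only one known. Compound 3 `CC(C)C[C@H](N)c1cc(C(F)(F)F)ccc1N1CCN(C(=O)C(C)Cc2ccc(Cl)cc2O)CC1` carries 1-(4-chloro-2-hydroxybenzyl)ethyl in place of (4-methylphenoxy)methyl on a carbonyl carbon. Among the compounds with values here, no measured step touches the carbonyl carbon; the step from compound 1 to compound 2 concerns the oxygen on a saturated carbon, so it gives no direct guidance. For compound 3 a step of a 1.5-fold lower number from compound 2 to compound 3 (0.17 log units; within the scatter) is expected, with no direction favoured beyond the scatter. The estimate for compound 3 is 3000 nM, in the range 500 nM to 15000 nM.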

Compound 3, inhibition constant: 36 nM
The estimate for compound 3 lay 83-fold (1.92 log units) above the measured number, outside the stated range (below it).
By their numbers in this assay, from the lowest: compound 3; then compound 1; then compound 2.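

At the carbonyl carbon, the side chain is a far stronger lever in this assay than the aryl change seen earlier: 1-(4-chloro-2-hydroxybenzyl)ethyl gives a 120-fold lower number from compound 2 to compound 3 (2.09 log units; beyond the scatter) and a 56-fold lower number from compound 1 to compound 3 (1.74 log units; beyond the scatter). The same large direction holds against both (4-methylphenoxy)methyl and ((naphthalen-2-yl)oxy)methyl, and the entering group adds a hydrogen-bond donor. Nothing available explains the gain.

Which part of the new group carries the gain remains open. Also open, as far as these compounds go, is whether an amine in place of its hydroxyl, or a bromine in place of its chlorine, would hold the number.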